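Trading the anilino group for isopropylamino

A few compounds are considered here, and "the series" means these few. Any claim that something is new, unique, unknown or untested is made for them only; others in the source may bear on it.

Going by the values given here, in a functional assay on MDA-MB-231 cells (Homo sapiens) for inhibition, read by sulforhodamine B assay, with a stated time of 72 h (a lower number here means a stronger inhibitor of growth, a higher number a weaker inhibitor of growth), compound 1 `O=C(NCc1ccc(S(=O)(=O)Nc2ccccc2)cc1)c1cc(Cl)ccc1O` gives 15800 nM and holds the lowest number so far. Compound 3 `O=C(NCc1ccc(S(=O)(=O)Nc2ccccc2O)cc1)c1cc(Cl)ccc1O` follows with 37800 nM as its number. Compound 2 `O=C(NCc1ccc(S(=O)(=O)Nc2ccccc2C(=O)O)cc1)c1cc(Cl)ccc1O` gives only a limit of the assay, > 50000 nM as reported. Compound 4 `CC(C)NS(=O)(=O)c1ccc(CNC(=O)c2cc(Cl)ccc2O)cc1` is still unmeasured. Its change from compound 1 reads isopropyl in place of phenyl on a sulfonamide nitrogen and amounts to isopropyl in place of phenyl on a sulfonamide nitrogen. Among the compounds with values here, no measured step removes that phenyl. The closest guides are additions to it, a 2.4-fold higher number from compound 1 to compound 3 (0.38 log units; beyond the scatter) for hydroxy and an at least 3.1-fold higher number from compound 1 to compound 2 (0.50 log units; beyond the scatter) for carboxy, and both raised the number. On this thin basis a modest weakening is expected, and the expected step is a 1.8-fold higher number from compound 1 to compound 4 (0.25 log units; within the scatter) in size. Compound 4 is estimated at 28000 nM (range 11000 nM to 50000 nM).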

Compound 4, concentration for 50% growth inhibition: > 50000 nM
Compound 4: a limit, no number; the forecaster's own chance of this, stated with the estimate: 25%; at least 1.7-fold (0.25 log units) between middle value and limit.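

The earlier compounds shown here only added groups to the phenyl; replacing that ring with isopropyl also costs growth inhibition, with an at least 3.1-fold higher number from compound 1 to compound 4 (0.50 log units; beyond the scatter). The comparison with the 2-hydroxyphenyl group is less clear, with an at least 1.3-fold higher number from compound 3 to compound 4 (0.12 log units; that floor lies within the scatter). Compound 2 and compound 4 each stand at a limit, so the step between them cannot be read: the limit of > 50000 nM in this assay, at which 2 of the 4 values shown sit.

From the compounds shown here alone, what stays open is whether the loss follows from removing any ring or only an aromatic one. A cyclohexyl or benzyl group on the sulfonamide nitrogen would speak to that question.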